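This account rests on a few compounds, and the source may have more. Where it says the series, first, only, none or still open, it means among the compounds named here.

Of the compounds shown here, three sharing one core have been tested in a functional assay on the whole organism with Mus musculus as the target; a lower number here means that less compound is needed, a higher number that more compound is needed for the effect. Compound 1, `c1ccc(CNCc2nnc(-c3ccccc3-c3ccccc3)s2)cc1`, gives 37 mg/kg; compound 2, `NCc1nnc(-c2ccccc2-c2ccccc2)s1`, gives 20 mg/kg; and compound 3, `CN(C)Cc1nnc(-c2ccccc2-c2ccccc2)s1`, gives 32 mg/kg. Compound 1 stands highest of the three numbers, but its distance to compound 3 is a 1.2-fold lower number from compound 1 to compound 3 (0.06 log units; within the scatter) and to compound 2 is a 1.9-fold lower number from compound 1 to compound 2 (0.27 log units; within the scatter), so the three sit together within the scatter.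

Compound 4, `NCCCc1nnc(-c2ccccc2-c2ccccc2)s1`, is not yet measured. It differs from compound 1 in this way: 2-aminoethyl in place of benzylamino on a saturated chain carbon bound to an aromatic carbon. Two of the measured steps bear on this change. The step from compound 1 to compound 2, which also removes the benzyl, is a 1.9-fold lower number from compound 1 to compound 2 (0.27 log units; within the scatter); the step from compound 2 to compound 3, which alters the substitution on the amine nitrogen, is a 1.6-fold higher number from compound 2 to compound 3 (0.20 log units; within the scatter). Both are within the scatter, as is a 1.2-fold lower number from compound 1 to compound 3 (0.06 log units; within the scatter). Nothing in these three compounds suggests that changing the group on the saturated chain carbon bound to the aromatic carbon moves this assay beyond the scatter.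

Compound 4 is therefore expected to give about 26 mg/kg, with a range from 12 mg/kg to 55 mg/kg, which is a step of a 1.4-fold lower number from compound 1 to compound 4 (0.15 log units; within the scatter) and is expected to lie within the scatter.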

Compound 4, dose for half-maximal effect: > 200 mg/kg
Compound 4 was reported as a limit (the forecaster's own chance of this, stated with the estimate: 5%); at least 7.6-fold (0.88 log units) between middle value and limit.
By their numbers in this assay, from the lowest: compounds 2, 3 and 1 (each within the scatter of the next). At a limit, above all of these: compound 4.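

In this assay, compound 4 stands at a limit of the assay and not at a number: the limit of > 200 mg/kg in this assay, at which 1 of the 4 values shown sits. Read against that limit, the change lies beyond the scatter from each earlier compound, with an at least 5.4-fold higher number from compound 1 to compound 4 (0.73 log units; beyond the scatter), an at least 6.2-fold higher number from compound 3 to compound 4 (0.79 log units; beyond the scatter) and an at least 10-fold higher number from compound 2 to compound 4 (1.00 log units; beyond the scatter). The earlier compounds shown here showed benzylamino, dimethylamino and amino on the saturated chain carbon bound to an aromatic carbon, all within the scatter of each other, whereas this result shows that the position does respond to a change of group, and that neither the nitrogen nor the size of the group decides this alone, since the much larger benzylamino and the smaller amino both stay in the same range while 2-aminoethyl, which has no ring, does not.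

Going by these compounds, a limit gives no size for the loss, so how far compound 4 really stands from the others remains open. On these data alone, it is also open whether the effect follows the length of the chain, which aminomethyl or a longer chain carrying an amine would test, or the amine itself, which hydroxyethyl would test.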